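Moving the side chain from compound 3 to compound 4

This account rests on a few compounds, and the source may have more. Where it says the series, first, only, none or still open, it means among the compounds named here.

In a functional assay on DU-145 cells (Homo sapiens) for antiproliferative activity, read by sulforhodamine B assay, with a stated time of 3 days (a lower number here means a stronger inhibitor of growth, a higher number a weaker inhibitor of growth), three compounds with a shared core have been measured so far. Compound 1 (`O=C(Nc1cccc(Nc2ncc(F)c(Nc3ccc(F)cc3)n2)c1)c1cnccn1`) gives 26400 nM and compound 2 (`CN1CCC(C(=O)Nc2cccc(Nc3ncc(F)c(Nc4ccc(F)cc4)n3)c2)CC1`) gives 1150 nM while compound 3 (`COCC(=O)Nc1cccc(Nc2ncc(F)c(Nc3ccc(F)cc3)n2)c1`) gives 4460 nM and so holds the second highest number of the three.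

Compound 4 (`O=C(NCCO)c1cccc(Nc2ncc(F)c(Nc3ccc(F)cc3)n2)c1`) has the same atoms as compound 3, joined differently ((2-hydroxyethyl)carbamoyl in place of ((methoxymethyl)carbonyl)amino on an aromatic carbon): (2-hydroxyethyl)carbamoyl in place of ((methoxymethyl)carbonyl)amino on an aromatic carbon.

The measured steps only swap the group on a carbonyl carbon: one large (a 23-fold lower number from compound 1 to compound 2 (1.36 log units; beyond the scatter)) and two modest (a 5.9-fold lower number from compound 1 to compound 3 (0.77 log units; beyond the scatter); a 3.9-fold higher number from compound 2 to compound 3 (0.59 log units; beyond the scatter)). They show that such swaps can move the number, but none of them rearranges the link to the core as compound 4 does, so they give no direction. The estimate therefore stays close to compound 3 (4460 nM) with a wide margin.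

The expected step is small (a 1.1-fold higher number from compound 3 to compound 4 (0.05 log units; within the scatter)) and no clear shift is foreseen. For compound 4 the estimated value is 5000 nM (expected range 1500 nM to 17000 nM).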

Compound 4, concentration for 50% growth inhibition: 13400 nM
For compound 4 the middle estimate is 2.7-fold (0.43 log units) below the measured one; the measured number falls inside the stated range.
By their numbers in this assay, from the lowest: compound 2; then compound 3; then compounds 4 and 1 (each within the scatter of the next).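

Rearranging the link to the core is not a neutral change in this assay: with the same atoms, swapping ((methoxymethyl)carbonyl)amino for (2-hydroxyethyl)carbamoyl gives a 3.0-fold higher number from compound 3 to compound 4 (0.48 log units; beyond the scatter), so how this side chain is joined to the aromatic carbon counts, not only what it contains. Replacing ((1-methylpiperidin-4-yl)carbonyl)amino with the same group gives a 12-fold higher number from compound 2 to compound 4 (1.07 log units; beyond the scatter), the larger of these two steps. Replacing ((pyrazin-2-yl)carbonyl)amino with it gives a 2.0-fold lower number from compound 1 to compound 4 (0.29 log units; within the scatter), so those two compounds cannot be told apart.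

No measurement available here gives a reason for these steps. Going by these compounds, it remains open whether a longer chain, an amine or a carboxylic acid in place of the hydroxyl end of (2-hydroxyethyl)carbamoyl would change the number in this assay.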